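The compounds below may be only part of what the source reports. "The series", "measured", "known", "first", "only" and "open" are said of these compounds alone.

Compound 1 `CCNC(=O)C1=C(C)NC(=O)NC1c1ccco1` and compound 2 `CC1=C(C(=O)NC(C)C)C(c2ccco2)NC(=O)N1` share a core and differ only in the group carried on the amide nitrogen. In an assay on membranes from HEK293 cells for displacement of a labelled ligand from adenosine receptor A2b (Homo sapiens), read by scintillation counting, with a stated time of 30 min, tested at 1 uM (on this read-out lower numbers stand for less inhibition and higher numbers for more inhibition at the one concentration tested (going by the name of the read-out)), compound 1 gives 1%. In this assay compound 2 gives 2%. For the measured compounds named here, the step between them is a number 1 percentage points higher from compound 1 to compound 2 (within the scatter), so on the numbers so far compound 2 and compound 1 cannot be told apart: both sit close to zero inhibition, and compound 2 stands nowhere that compound 1 does not also stand.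

Compound 3 `CCN(CC)C(=O)C1=C(C)NC(=O)NC1c1ccco1` carries the change (diethylamino in place of isopropylamino on a carbonyl carbon). Going by the values given here, the only measured step that bears on this, the one from compound 1 to compound 2, also altered the substituent on the amide nitrogen and stayed within the scatter, with a number 1 percentage points higher from compound 1 to compound 2 (within the scatter). Nothing measured suggests that a larger or a further-branched group on that nitrogen moves the read-out. The expected step of no change at the digits printed from compound 2 to compound 3 (within the scatter) is therefore none beyond the scatter. Compound 3 is estimated to give 2% in this assay, with a likely range from -8% to 12%.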

Compound 3, a percentage reported as inhibition, at one concentration (the size of the read-out at that concentration, not a potency): 31%
Beside the measured number, compound 3's estimate is 29 percentage points below it, outside the stated range (above it).
By their numbers in this assay, from the lowest: compounds 1 and 2 (each within the scatter of the next); then compound 3.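

In this assay, the group on the carbonyl carbon turns out to be a place where the read-out can move: diethylamino in place of isopropylamino gives a number 29 percentage points higher from compound 2 to compound 3 (beyond the scatter), and ethyl in place of hydrogen on the amide-type nitrogen gives a number 30 percentage points higher from compound 1 to compound 3 (beyond the scatter). The earlier step, in which the nitrogen kept its hydrogen while its chain grew from ethyl to isopropyl, stayed within the scatter, so a larger group alone did not move the number in that one case, whereas here the nitrogen carries two ethyl chains and the amide hydrogen is gone. Nothing at hand shows what lies behind this rise.

Since compound 3 both loses the amide hydrogen and gains carbon atoms, the compounds shown leave open which of the two goes with the higher number. Dimethylamino would show whether a nitrogen without hydrogen carrying shorter chains keeps the number, and dipropylamino would show whether longer chains on that nitrogen take it further.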